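From bromo to methylsulfanyl on a shared core

The source may hold more compounds than are shown below. What is called first, only, known or untested is meant among the compounds shown, and "the series" means these compounds.

Compound 1 `CCCCOC[C@H]1O[C@@H](n2c(Cl)nc3cc(Cl)c(Cl)cc32)[C@H](OC(C)=O)[C@@H]1OC(C)=O` gives > 100000 nM (a limit)
Compound 2 `CC(=O)OC1C(CBr)OC(n2c(Cl)nc3cc(Cl)c(Cl)cc32)C1OC(C)=O` gives 60000 nM (a number)

For the measured compounds named here, in a functional assay on KB cells (Homo sapiens) for inhibition (on this read-out lower numbers stand for stronger inhibition and higher numbers for weaker inhibition), compound 2 gives 60000 nM as the only true number so far. Compound 1 stands at > 100000 nM in this assay and this is a limit, not a number. Going by the values given here, compound 3 `CSCC1OC(n2c(Cl)nc3cc(Cl)c(Cl)cc32)C(OC(C)=O)C1OC(C)=O` keeps the core of compound 2 and carries methylsulfanyl in place of bromo on a saturated chain carbon bound to a saturated ring carbon as its one change. Among the compounds with values here, no measured pair shows this exchange, so the expectation rests on compound 2 at 60000 nM alone, with a small shift toward weaker inhibition in this assay or none beyond the scatter. The expected move is a 1.3-fold higher number from compound 2 to compound 3 (0.12 log units; within the scatter) and no larger shift is foreseen. For compound 3 the estimated value is 80000 nM within an expected range of 30000 nM to 150000 nM and the assay may report only a limit.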

Compound 3, half-maximal inhibitory concentration: 70000 nM
Estimate against measurement, compound 3: 1.1-fold (0.06 log units) above; low and high end bracket the measured number.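

In this assay, for the compounds shown here, methylsulfanyl in place of bromo on a saturated chain carbon bound to a saturated ring carbon gives a 1.2-fold higher number from compound 2 to compound 3 (0.07 log units; within the scatter), the first pair in which this position can be read. The bromo is therefore not needed for the reading seen with compound 2: a group with a different heavy-atom count and one hydrogen-bond acceptor gives a value that cannot be told apart from it. Both numbers stay close to the point at which this assay stops giving numbers: the limit of > 100000 nM in this assay, at which 1 of the 3 values shown sits.

The compounds shown leave open whether any group at this place can move the number beyond the scatter, as a single exchange cannot settle this. An amine or a carboxylic acid on that carbon, or a longer chain on the sulfur, would bear on that question.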